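Swapping 2-methylphenyl for 2-fluorophenyl on compound 1

A few compounds are considered here, and "the series" means these few. Any claim that something is new, unique, unknown or untested is made for them only; others in the source may bear on it.

Going by the values given here, in a functional assay on HCT-116 cells (Homo sapiens) for inhibition, read by MTT assay, with a stated time of 72 h (a lower number here means a stronger inhibitor, a higher number a weaker inhibitor), compound 1 (`COc1cc2c(Oc3ccc(NC(=O)c4nn(-c5ccccc5C)cc(C)c4=O)cc3)ccnc2cc1OCCCC(=O)NO`) gives 640 nM, the higher of the two numbers so far, and compound 2 (`COc1cc2c(Oc3ccc(NC(=O)c4nn(-c5ccccc5C)cc(C)c4=O)cc3)ccnc2cc1OCCCCCC(=O)NO`) gives 290 nM. Compound 3 (`COc1cc2c(Oc3ccc(NC(=O)c4nn(-c5ccccc5F)cc(C)c4=O)cc3)ccnc2cc1OCCCC(=O)NO`) has fluoro in place of methyl on an aromatic carbon. Among the compounds with values here, the only measured step, a 2.2-fold lower number from compound 1 to compound 2 (0.34 log units; beyond the scatter), is modest and lies on the saturated chain, so no measurement tests this aromatic swap directly. The expected change is a 1.1-fold lower number from compound 1 to compound 3 (0.03 log units; within the scatter), with no shift beyond the scatter in either direction. For compound 3 the estimated value is 600 nM, with a range of 250 nM to 1400 nM.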

Compound 3, half-maximal inhibitory concentration: 950 nM
Estimate against measurement, compound 3: 1.6-fold (0.20 log units) below, within the range that was stated.
By their numbers in this assay, from the lowest: compound 2; then compounds 1 and 3 (each within the scatter of the next).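

In this assay, the change from 2-methylphenyl to 2-fluorophenyl gives a 1.5-fold higher number from compound 1 to compound 3 (0.17 log units; within the scatter), so this swap on an aromatic carbon, ortho to a large group, produces no change that stands clear of the scatter. At this place, with the shorter chain of compound 1, fluoro and methyl cannot be told apart. Nothing measured here offers an explanation for this result. As far as these compounds go, whether the swap behaves the same way on the longer chain of compound 2 remains open. So does the effect of a quite different group here, such as an amine or a nitrile.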